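The source may report more compounds than this note shows. Statements on the series, on what has been measured and on what is new or still open speak of the compounds shown alone.

Measured so far in an assay on isolated protein for displacement of a labelled ligand from metabotropic glutamate receptor 5 (Homo sapiens), with a stated time of 60 min, tested at 1 uM; a lower number here means less inhibition, a higher number more inhibition at the concentration tested (going by the name of the read-out):
compound 1 `CC1CCN(c2c(S(=O)(=O)c3ccc(Cl)cc3)cnc3c(F)cccc23)CC1`, 85%
compound 2 `Cc1ccc(S(=O)(=O)c2cnc3c(F)cccc3c2N2CCC(C)CC2)cc1F`, 93%
compound 3 `CC1CCN(c2c(S(=O)(=O)c3ccc(F)c(F)c3)cnc3c(F)cccc23)CC1`, 93%

Compound 3 stands level with compound 2 at the digits printed, and the two together are the highest of the three numbers. Both steps leading to it, a number 8 percentage points higher from compound 1 to compound 3 (within the scatter) and no change at the digits printed from compound 2 to compound 3 (within the scatter), lie within the scatter, as does a number 8 percentage points higher from compound 1 to compound 2 (within the scatter); across the series the aryl group on the sulfonyl sulfur has so far not moved this assay beyond noise.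

Compound 4 `CC1CCN(c2c(S(=O)(=O)c3cccc(F)c3)cnc3c(F)cccc23)CC1` differs from compound 3 by hydrogen in place of fluoro on an aromatic carbon. For the measured compounds named here, no measured step removes a substituent from this ring; the nearest comparisons, no change at the digits printed from compound 2 to compound 3 (within the scatter) and a number 8 percentage points higher from compound 1 to compound 3 (within the scatter), were both within the scatter. The expected step is therefore a number 5 percentage points lower from compound 3 to compound 4 (within the scatter), none beyond the scatter. Compound 4 is estimated at 88%, range 74% to 97%.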

Compound 4, a percentage reported as inhibition, at one concentration (the size of the read-out at that concentration, not a potency): 62%
The estimate for compound 4 lay 26 percentage points above the measured number, and the stated range ends above it.
By their numbers in this assay, from the lowest: compound 4; then compounds 1, 2 and 3 (each within the scatter of the next).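

The aryl group on the sulfonyl sulfur does matter in this assay: with hydrogen on the aromatic carbon para to a large group, the result is a number 31 percentage points lower from compound 3 to compound 4 (beyond the scatter) against fluoro and a number 31 percentage points lower from compound 2 to compound 4 (beyond the scatter) against methyl. Replacing 4-chlorophenyl with 3-fluorophenyl gives a number 23 percentage points lower from compound 1 to compound 4 (beyond the scatter) and so, in these four compounds, fluoro, methyl and chloro on that carbon all stand apart from hydrogen. Nothing available explains this loss.

Going by these compounds, whether methoxy, an amine or a nitrile on that carbon would hold the number remains open. So does what the remaining fluoro of compound 4 contributes, which an unsubstituted phenyl on the sulfonyl sulfur would settle.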